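From a Propyl to a Carboxymethyl Chain

The source may report more compounds than this note shows. Statements on the series, on what has been measured and on what is new or still open speak of the compounds shown alone.

Within the data shown here, only two compounds have numbers so far. In a functional assay on the whole organism with Rattus norvegicus as the target (on this read-out higher numbers stand for an effect only at larger amounts of compound and lower numbers for an effect already at smaller amounts), compound 1 `Nc1nc2ccc(SC(F)(F)F)cc2s1` gives 8 mg/kg and compound 2 `CCCn1c(=N)sc2cc(OC(F)(F)F)ccc21` gives 4.5 mg/kg. These two values lie within the usual scatter of each other, so the data do not separate them, even though compound 2 carries the lower number of the pair.

Compound 3 `N=c1sc2cc(OC(F)(F)F)ccc2n1CC(=O)O` keeps the core of compound 2 and alters a single place. The propyl becomes carboxymethyl, which means carboxy in place of ethyl on a saturated chain carbon bound to an aromatic nitrogen.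

Among the measured compounds shown here, no measured pair of compounds differs in just one place, so the data offer no direct precedent for this change. The expectation therefore rests on the structural change alone and remains uncertain. In this assay, a clear shift towards a higher number is expected, beyond the scatter, meaning that larger amounts of compound would be needed for the same effect. The expected size of this move is a 6.7-fold higher number from compound 2 to compound 3 (0.82 log units; beyond the scatter). For compound 3 the estimate is 30 mg/kg, with an expected range from 9 mg/kg to 100 mg/kg.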

Compound 3, dose for half-maximal effect: > 10 mg/kg
Compound 3: a limit, no number (the forecaster's own chance of this, stated with the estimate: 20%); the middle value lies beyond the limit too.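

Among these compounds, this is the first step between two compounds that differ in one place, and it shows that the position is not indifferent to what it carries. In this assay, replacing propyl with carboxymethyl, that is, carboxy in place of ethyl on a saturated chain carbon bound to an aromatic nitrogen, gives an at least 2.2-fold higher number from compound 2 to compound 3 (0.34 log units; beyond the scatter), so the change moves the read-out beyond the scatter towards larger amounts of compound. In this assay compound 3 gives > 10 mg/kg, which is a limit and not a number. The step therefore fixes only the smallest size the change can have, and its full size stays unread because the value behind it is a limit: the limit of > 10 mg/kg in this assay, at which 1 of the 3 values shown sits.

A single step cannot tell whether the shift comes from adding the carboxy group or from losing the ethyl, and it cannot show how the position responds to other kinds of group. A methyl ester, a primary amide, an amine or a longer chain at this place would help separate these possibilities, and a plain butyl chain would show what chain length alone does.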